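This account rests on a few compounds, and the source may have more. Where it says the series, first, only, none or still open, it means among the compounds named here.

Of the compounds shown here, three built on one shared core have been tested for cytotoxicity in a functional assay on WI-38 VA13 cells (Homo sapiens) for cytotoxicity; a higher number here means that more compound is needed for the effect, a lower number that less compound is needed. Compound 1 `O=C(Nc1ccc2nc(NC(=O)C3CCCCC3)sc2c1)c1cccnc1Cl` gives 0.075 ug/mL. Compound 2 `Cc1cc(C(=O)Nc2ccc3nc(NC(=O)C4CCCCC4)sc3c2)c(C)n1C` gives only a limit, > 6.2 ug/mL, so no number exists for it. Compound 3 `CC(C)CC(=O)Nc1nc2ccc(NC(=O)c3c(Cl)cccc3Cl)cc2s1` gives 0.012 ug/mL, the lowest of the two numbers, with compound 1 the nearest and that gap beyond the scatter. Going by the values given here, the only measured step, an at least 82-fold higher number from compound 1 to compound 2 (1.91 log units; beyond the scatter), changes a different group, the one on the carbonyl carbon, and runs into (the limit of > 6.2 ug/mL in this assay, at which 1 of the 3 values shown sits). Compound 4 `CCCCCNc1nc2ccc(NC(=O)c3c(Cl)cccc3Cl)cc2s1` differs from compound 3 by pentyl in place of isobutylcarbonyl on a nitrogen on an aromatic ring. Among the compounds with values here, no measured step covers a change of this kind, so the expectation rests on compound 3 alone and is loosely held. Compound 4 is expected to need somewhat more compound, roughly a 4.2-fold higher number from compound 3 to compound 4 (0.62 log units; beyond the scatter). The number for compound 4 is therefore estimated at 0.05 ug/mL, within a range from 0.01 ug/mL to 0.3 ug/mL.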

Compound 4, half-maximal effective concentration: 0.27 ug/mL
Compound 4: middle estimate off by 5.4-fold (0.73 log units), on the low side; the measured number falls inside the stated range.
By their numbers in this assay, from the lowest: compound 3; then compound 1; then compound 4. At a limit, above all of these: compound 2.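

In this assay, replacing isobutylcarbonyl with pentyl on this nitrogen gives a 23-fold higher number from compound 3 to compound 4 (1.35 log units; beyond the scatter), so this position, which the earlier step left untouched, also moves the number strongly. Neither group has a ring, but the change removes the carbonyl and its hydrogen-bond acceptor, leaving a chain with no acceptor. Nothing measured here gives a reason for the size of this step.

This one pair cannot show whether the step follows the loss of the carbonyl or the change in chain shape, a question that a pentanoyl group on the same nitrogen could help to separate. Also open, from the compounds shown here alone, is how this assay would read with a chain ending in an amine or a carboxylic acid at this position.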